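Notes on the step from compound 2 to compound 4

The source may report more compounds than this note shows. Statements on the series, on what has been measured and on what is new or still open speak of the compounds shown alone.

Measured in a toxicity assay on HepG2 cells (Homo sapiens) for inhibition, read by resazurin assay, with a stated time of 24 h; a higher number here means that more compound is tolerated, a lower number that less compound is tolerated:
compound 1 `CN(C)C(=O)c1ncc([N+](=O)[O-])n1C` gives > 100000 nM, a limit
compound 2 `CN(C)C(=O)c1ncc([N+](=O)[O-])[nH]1` gives > 100000 nM, a limit
compound 3 `O=C(NC1CCCCC1)c1ncc([N+](=O)[O-])[nH]1` gives > 100000 nM, a limit

Compound 2 stands only at a limit and has no number. Compound 4 `O=C(NCCO)c1ncc([N+](=O)[O-])[nH]1` differs from it as follows: (2-hydroxyethyl)amino in place of dimethylamino on a carbonyl carbon. Within the data shown here, the only measured step nearby, a step that the two limits leave unreadable from compound 1 to compound 2, has no readable size and concerns an aromatic nitrogen, not the carbonyl carbon. Compound 3 also stays at a limit in this assay, with > 100000 nM as its value. No step beyond the scatter is therefore expected in this assay, because of the limit of > 100000 nM in this assay, at which 3 of the 3 values shown sit. The estimated step is a step that the limit leaves unreadable from compound 2 to compound 4. For compound 4 the expected value is 120000 nM, with an estimated range from 50000 nM to 300000 nM.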

Compound 4, half-maximal cytotoxic concentration: > 100000 nM
Compound 4: only a limit was reported; the forecaster's own chance of this, stated with the estimate: 85%; the middle value does not contradict the limit.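

Compound 2 and compound 4 both stand only at a limit in this assay, and no step between them can be read: the limit of > 100000 nM in this assay, at which 4 of the 4 values shown sit.

The compounds shown leave open whether any change on the carbonyl carbon shifts the tolerated concentration in this assay.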